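Cytotoxicity of three amides after changing the aryl group

The compounds below may be only part of what the source reports. "The series", "measured", "known", "first", "only" and "open" are said of these compounds alone.

Compound 1 `CC(=O)Nc1cccc(-c2ccc(C(=O)N(Cc3cccc(OCCCCCC(=O)O)c3)C(C)C)cc2)c1` gives in an ADME assay on HepG2 cells (Homo sapiens) for cytotoxicity, read by CellTiter-Glo and resazurin assay, with a stated time of 72 h (a higher number here means that more compound is needed for the effect, a lower number that less compound is needed), a limit of > 26000 nM.
Compound 2 `CC(C)N(Cc1cccc(OCCCCCC(=O)O)c1)C(=O)c1ccc(-c2ccc3cc[nH]c3c2)cc1` gives in this assay a limit of > 26000 nM.

Within the data shown here, compound 2 thus stands at a limit of this assay, not at a number, and the same holds for the one other compound measured, as the limit of > 26000 nM in this assay, at which 2 of the 2 values shown sit, shows. The step that the two limits leave unreadable from compound 1 to compound 2 therefore cannot be read in size or direction.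

Compound 3 `CC(C)N(Cc1cccc(OCCCCCC(=O)O)c1)C(=O)c1ccc(-c2ccc(Cl)c(Cl)c2)cc1` is not yet measured. It differs from compound 2 by 3,4-dichlorophenyl in place of 1H-indol-6-yl on an aromatic carbon. Among the measured compounds shown here, the only measured step that bears on this comparison is the one from compound 1 to compound 2, and it is unreadable, so no size of change in this assay can be drawn from it. Both measured compounds sit at the limit, and compound 3 is expected to do the same rather than to show a readable effect.

The step from compound 2 to compound 3 is therefore expected to be a step that the limit leaves unreadable from compound 2 to compound 3. Compound 3 is estimated to give 30000 nM in this assay, with a range from 12000 nM to 80000 nM, most likely reported again as a limit.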

Compound 3, half-maximal effective concentration: > 26000 nM
Compound 3 ended at the assay's limit; the forecaster's own chance of this, stated with the estimate: 70%; the middle value lies beyond the limit too.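

Compound 3 also ended at a limit rather than a number, so none of the steps among compound 1, compound 2 and compound 3 can be read in size or direction: the limit of > 26000 nM in this assay, at which 3 of the 3 values shown sit.

The compounds shown leave open where the true value of each lies, and whether changing the aryl group alters the result in this assay at all.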